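Flipping one stereocentre of compound 3

The source may report more compounds than this note shows. Statements on the series, on what has been measured and on what is new or still open speak of the compounds shown alone.

In an ADME assay on microsomes from liver (Homo sapiens) for metabolic stability, with a stated time of 10 min (a lower number here means that less of the compound is left, a higher number that more of the compound is left), compound 1 (`COc1ccccc1-n1nc(C2CC(C)(C)OC(C)(C)C2)cc1-c1ccc(Cl)cc1`), with its 2,2,6,6-tetramethyloxan-4-yl group, gives 97% and compound 2 (`COc1ccccc1-n1nc(C2CCOC(C)(C)C2)cc1-c1ccc(Cl)cc1`), with 2,2-dimethyloxan-4-yl, gives 98% on the same scale. The step between them (a number 1 percentage points higher from compound 1 to compound 2 (within the scatter)) stays within the scatter. Compound 3 (`COc1ccccc1-n1nc([C@@H]2CCO[C@@H](C(C)C)C2)cc1-c1ccc(Cl)cc1`), which carries 2-isopropyloxan-4-yl, stands lowest of the three at 26% of the compound remaining. Both steps leading to it are large and beyond the scatter (a number 71 percentage points lower from compound 1 to compound 3 (beyond the scatter) and a number 72 percentage points lower from compound 2 to compound 3 (beyond the scatter)).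

Compound 4 (`COc1ccccc1-n1nc([C@@H]2CCO[C@H](C(C)C)C2)cc1-c1ccc(Cl)cc1`) has the same atoms and bonds as compound 3 and departs from it in configuration alone (the two compounds have the same atoms and bonds and differ only in configuration as drawn: 1 of 2 stereo elements differ; a stereocentre at a saturated ring carbon is drawn R in compound 3 and S in compound 4). Among the compounds with values here, no measured step isolates a change of configuration, so the data give no direction for this one. Within the data shown here, they show only that the values moved widely when the group itself was replaced, and that keeps the range broad. The central expectation is therefore no step beyond the scatter, and the estimated change (a number 8 percentage points higher from compound 3 to compound 4 (within the scatter)) is small, with only a slight lean upward. Compound 4 is expected at 34% (estimated range 10% to 75%).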

Compound 4, percent of the compound remaining: 66%
Compound 4: the middle estimate sits 32 percentage points below what was measured; measured number inside the range.
By their numbers in this assay, from the lowest: compound 3; then compound 4; then compounds 1 and 2 (each within the scatter of the next).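

In this assay, the configuration at a saturated ring carbon of the 2-isopropyloxan-4-yl group turns out to matter on its own: the step it carries (a number 40 percentage points higher from compound 3 to compound 4 (beyond the scatter)) is large, whereas the earlier compounds had shown large steps only when the group itself was replaced. The low number of compound 3 therefore does not belong to 2-isopropyloxan-4-yl as such, yet compound 4, with the same group, still shows large steps against the two methyl-bearing groups (a number 32 percentage points lower from compound 2 to compound 4 (beyond the scatter) and a number 31 percentage points lower from compound 1 to compound 4 (beyond the scatter)), so both the group and its configuration count here. The change between compound 3 and compound 4 can be laid to configuration alone because nothing else separates them: the fact that compounds 3 and 4 differ only in the configuration as drawn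

The compounds shown leave open what the other stereocentre contributes, as only one of the two differs within this pair, and why one configuration leaves more of the compound than the other. They also leave open whether configuration matters to the same degree with a 2-ethyl or a 2-tert-butyl group on the oxane in place of isopropyl.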